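The compounds below may be only part of what the source reports. "The series", "measured", "known", "first", "only" and "open" are said of these compounds alone.

Measured in an ADME assay on HEK293 cells (Homo sapiens) for cytotoxicity, read by MTT assay, with a stated time of 72 h; on this read-out higher numbers stand for weaker inhibition and lower numbers for stronger inhibition:

- compound 1 `COc1ccc(C2=C(c3cc(OC)c(OC)c(OC)c3)C(=O)CC2O[SiH2]C(C)(C)C)cc1`: > 100 ug/mL
- compound 2 `COc1ccc(C2=C(c3cc(OC)c(OC)c(OC)c3)C(=O)CC2O)cc1O`: > 100 ug/mL
- compound 3 `COc1cc(C2=C(c3cc(C)c(OC)c(C)c3)C(O[SiH2]C(C)(C)C)CC2=O)cc(OC)c1OC`: 29 ug/mL

Within the data shown here, compound 3 stands alone here, with 29 ug/mL as the only actual number of the three. The other two readings are not numbers but limits of the assay, and the shared reading is the limit of > 100 ug/mL in this assay, at which 2 of the 3 values shown sit.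

Compound 4 `COc1ccc(C2=C(c3cc(OC)c(OC)c(OC)c3)C(=O)CC2O[SiH2]C(C)(C)C)cc1O` has not yet been measured. It differs from compound 3 in one place: 3-hydroxy-4-methoxyphenyl in place of 4-methoxy-3,5-dimethylphenyl on a double-bonded ring carbon. In words, 3-hydroxy-4-methoxyphenyl replaces 4-methoxy-3,5-dimethylphenyl on a double-bonded ring carbon.

Two results bear on this change. Among the measured compounds shown here, the departing group is the one that entered in the only measured step, an at least 3.4-fold lower number from compound 1 to compound 3 (0.53 log units; beyond the scatter). As far as these compounds go, that step lies beyond the scatter, and its true size is unknown since it starts from a limit. Compound 2 already carries the entering group, and its > 100 ug/mL is a limit too.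

Losing the group that came with the lower number should therefore undo much of that step, moving this assay towards higher numbers. The expected change is a 2.6-fold higher number from compound 3 to compound 4 (0.41 log units; beyond the scatter). A reading at the limit would be no surprise. For compound 4 the estimated value is 75 ug/mL, with an expected range of 30 ug/mL to 180 ug/mL.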

Compound 4, half-maximal inhibitory concentration: 42 ug/mL
For compound 4 the middle estimate is 1.8-fold (0.25 log units) above the measured one; low and high end bracket the measured number.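

In this assay, exchanging the two aryl groups on the double-bonded ring carbon gives a 1.4-fold higher number from compound 3 to compound 4 (0.16 log units; within the scatter), so the 4-methoxy-3,5-dimethylphenyl and 3-hydroxy-4-methoxyphenyl groups cannot be told apart here, and the dimethyl pattern is not the only route to a measurable number. Two further steps show that compound 4 owes its reading to two features together: hydroxy in place of hydrogen on an aromatic carbon gives an at least 2.3-fold lower number from compound 1 to compound 4 (0.37 log units; beyond the scatter), and a group of 5 heavy atoms in place of hydrogen on the oxygen on a saturated carbon gives an at least 2.3-fold lower number from compound 2 to compound 4 (0.37 log units; beyond the scatter). Both steps start from a limit rather than a number, so they give only a minimum size: the limit of > 100 ug/mL in this assay, at which 2 of the 4 values shown sit.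

The compounds shown leave open whether an amine in place of the hydroxy on the aromatic ring would give a similar reading in this assay. They also leave open how much of the group of 5 heavy atoms is needed, since a simple methyl group on that same oxygen would test whether a smaller group gives a comparable number.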